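A few compounds are considered here, and "the series" means these few. Any claim that something is new, unique, unknown or untested is made for them only; others in the source may bear on it.

Compound 3 `Cc1ccc2cc(CN(Cc3ccc(F)cc3)Cc3ccc(C(C)(C)C)cc3)c(=O)[nH]c2c1` belongs to a set of three close relatives that share one core. Compound 1 `Cc1ccc2cc(CN(Cc3ccc(F)cc3)Cc3ccc(C(C)C)cc3)c(=O)[nH]c2c1` in a toxicity assay on MDCK cells (Canis lupus familiaris) for cytotoxicity, read by crystal violet staining, with a stated time of 48 h (a lower number here means that less compound is tolerated, a higher number that more compound is tolerated), gives a limit of the assay, > 33000 nM, and no number. Compound 2 `Cc1ccc2cc(CN(Cc3ccc(Cl)cc3)Cc3ccc(C(C)C)cc3)c(=O)[nH]c2c1` in this assay likewise gives only a limit, > 33000 nM. Compound 3 itself in this assay gives a limit too, > 33000 nM. Accordingly the two measured changes, a step that the two limits leave unreadable from compound 1 to compound 2 and a step that the two limits leave unreadable from compound 1 to compound 3, cannot be sized, since (the limit of > 33000 nM in this assay, at which 3 of the 3 values shown sit).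

Compound 4 `CCc1ccc(CN(Cc2ccc(F)cc2)Cc2cc3ccc(C)cc3[nH]c2=O)cc1` differs from compound 3 in one place: ethyl in place of tert-butyl on an aromatic carbon. No measured change in this set resembles it, and the measured changes that exist are themselves unreadable, so no size or direction beyond the scatter can be taken from them. What the set shows is only that every relative sits at the limit. It is therefore expected that compound 4 remains there as well, with an estimated step that the limit leaves unreadable from compound 3 to compound 4. The expected value for compound 4 in this assay is 50000 nM, within a range from 20000 nM to 200000 nM.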

Compound 4, half-maximal cytotoxic concentration: > 33000 nM
Compound 4: only a limit was reported; the forecaster's own chance of this, stated with the estimate: 85%; the middle value is on the limit's open side.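

The new steps from compound 3 to compound 4 and from compound 1 to compound 4 cannot be read, since each compound gives a limit and not a number: the limit of > 33000 nM in this assay, at which 4 of the 4 values shown sit. The compounds shown leave open whether ethyl in place of tert-butyl changes the tolerated concentration in this assay at all.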